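The compounds below may be only part of what the source reports. "The series", "measured", "known", "first", "only" and "open" are said of these compounds alone.

Compound 1 `OC[C@H]1O[C@@H](n2cnc3c(S)nccc32)C[C@@H]1O`: < 5%
Compound 2 `OC[C@H]1OC(n2cnc3c(S)nccc32)[C@H](O)[C@@H]1O`: < 5%

In a functional assay on EL4 cells (Mus musculus) for inhibition, tested at 100 uM (a lower number here means less inhibition, a higher number more inhibition at the concentration tested (going by the name of the read-out)), compound 1 gives only a limit, < 5%. Compound 2 likewise gives only a limit, < 5%. Both measured values rest at the same limit of the assay (the limit of < 5% in this assay, at which 2 of the 2 values shown sit), so compound 1 stands at the lowest point the measurements can show. Compound 3 `OC[C@H]1O[C@@H](n2cnc3cnccc32)C[C@@H]1O` has not been measured; it differs from compound 1 by hydrogen in place of sulfanyl on an aromatic carbon. Among the measured compounds shown here, no measured step exists to gauge this change, and since compound 1 already sits at the limit (the limit of < 5% in this assay, at which 2 of the 2 values shown sit), the step is expected to be none beyond the scatter a step that the limit leaves unreadable from compound 1 to compound 3. Compound 3 is therefore expected to give about 3%, between 0% and 12%.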

Compound 3, a percentage reported as inhibition, at one concentration (the size of the read-out at that concentration, not a potency): < 5%
Compound 3 ended at the assay's limit; the forecaster's own chance of this, stated with the estimate: 80%; the middle value is on the limit's open side.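

Among the compounds shown here, compound 1 and compound 3 both rest at the limit of this assay, so replacing sulfanyl with hydrogen gives no step that can be read. The compounds shown leave open whether this change affects inhibition at all, because none of them rises off the limit: the limit of < 5% in this assay, at which 3 of the 3 values shown sit.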